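Dropping One Chlorine from a Dichloro Purine Benzyl Series

The source may report more compounds than this note shows. Statements on the series, on what has been measured and on what is new or still open speak of the compounds shown alone.

Measured so far:
compound 1 `ClCc1cccc(Cn2cnc3ncnc(Cl)c32)c1` — 36300 nM
compound 2 `ClCc1ccc(Cn2cnc3nc(Cl)nc(Cl)c32)cc1` — 3310 nM
compound 3 `ClCc1ccccc1Cn1cnc2nc(Cl)nc(Cl)c21` — 4260 nM

In a functional assay on SF-539 cells (Homo sapiens) for cytotoxicity, read by sulforhodamine B assay, with a stated time of 48 h (on this read-out higher numbers stand for weaker inhibition of growth and lower numbers for stronger inhibition of growth), compound 2 gives the lowest of the three numbers. Compound 3 lies within the usual scatter of compound 2, so no order can be read between them; compound 1 lies well beyond that scatter and carries the highest number of the set.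

Compound 4 `ClCc1ccc(Cn2cnc3ncnc(Cl)c32)cc1` has not yet been measured in this assay. It differs from compound 2 by hydrogen in place of chloro on an aromatic carbon. Among the measured compounds shown here, no measured pair isolates this change. Compound 1 also carries a single chloro on the shared core, but its chloromethyl group sits at a different position of the benzyl ring, so the gap between compound 1 and compound 2 cannot be assigned to the chloro alone. For the measured compounds named here, still, the only single-chloro compound giving the highest number points toward a loss. The step of a 4.5-fold higher number from compound 2 to compound 4 (0.66 log units; beyond the scatter) is therefore expected to weaken growth inhibition beyond the scatter. Compound 4 is estimated at 15000 nM, between 4000 nM and 50000 nM.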

Compound 4, concentration for total growth inhibition: 3710 nM
Compound 4: middle estimate off by 4.0-fold (0.61 log units), on the high side, and the stated range ends above it.
By their numbers in this assay, from the lowest: compounds 2, 4 and 3 (each within the scatter of the next); then compound 1.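

In this assay, hydrogen in place of chloro on the aromatic carbon between two ring nitrogen atoms gives a 1.1-fold higher number from compound 2 to compound 4 (0.05 log units; within the scatter), within the scatter, so with the chloromethyl group in the same place, this chloro can go without a readable difference. Compound 4 gives 3710 nM and compound 1, which differs from it only in where the chloromethyl group sits on the benzyl ring, gives 36300 nM, so the high number of compound 1 does not follow from the missing chloro alone. No evidence at hand explains why this chloro makes no readable difference.

The compounds shown leave open whether an amine or a methoxy group on that same carbon would also stay within the scatter of compound 2. They also leave open what replacing the remaining chloro group with hydrogen or an amine would do.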